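The source may report more compounds than this note shows. Statements on the series, on what has been measured and on what is new or still open speak of the compounds shown alone.

Measured compounds:
Compound 1, `Cc1occc1-c1nnc(SCC(=O)Nc2cccc(F)c2)n1Cc1ccco1`, in a functional assay on CHO cells for antagonist activity at Orexin receptor type 2 (Homo sapiens), read by FLIPR and calcium flux; a lower number here means a stronger inhibitor, a higher number a weaker inhibitor: 501 nM
Compound 2, `COc1ccccc1NC(=O)CSc1nnc(-c2ccoc2C)n1Cc1ccco1`, in this assay: 501 nM
Compound 3, `Cc1cc(C)cc(N(C(=O)CSc2nnc(-c3ccoc3C)n2Cc2ccco2)c2ccccn2)c1`, in this assay: 398 nM

Compound 3 has the lowest of the three numbers in this assay, but its gaps to compound 1 and to compound 2 both lie within the usual scatter, so the three compounds stand together on the figures shown. Going by the values given here, the one step between measured compounds that differ in a single place, no change at the digits printed from compound 1 to compound 2 (within the scatter), exchanges one aryl group for another on the amide-type nitrogen and leaves the number unchanged.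

Compound 4, `Cc1cc(C)cc(N(C(=O)CSc2nnc(-c3ccoc3C)n2Cc2ccco2)C2CNCCN2)c1`, is the next member of the series. It differs from compound 3 in one place: piperazin-2-yl in place of pyridin-2-yl on an amide-type nitrogen. This change sits on the same amide-type nitrogen as the step from compound 1 to compound 2, so that step is the only one that bears on it; yet it showed no change for an aryl-for-aryl swap, whereas here an aromatic ring gives way to a non-aromatic one with two hydrogen-bond donors. Among the compounds with values here, no measured pair shows such a change, so the expectation is uncertain. Compound 4 is expected to give 1200 nM in this assay, in the range 300 nM to 6000 nM. The estimated step from compound 3 to compound 4 is a 3.0-fold higher number from compound 3 to compound 4 (0.48 log units; beyond the scatter), and a weaker result is judged more likely than a stronger one.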

Compound 4, inhibition constant: 631 nM
Compound 4: middle estimate off by 1.9-fold (0.28 log units), on the high side, within the range that was stated.
By their numbers in this assay, from the lowest: compounds 3, 1, 2 and 4 (each within the scatter of the next).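

In this assay the exchange of pyridin-2-yl for piperazin-2-yl on the amide-type nitrogen gives a 1.6-fold higher number from compound 3 to compound 4 (0.20 log units; within the scatter) and so places a six-membered aromatic ring and a six-membered non-aromatic ring with hydrogen-bond donors together on the figures shown. Going by these compounds alone, the earlier step at an amide-type nitrogen, no change at the digits printed from compound 1 to compound 2 (within the scatter), only exchanged one aryl group for another, so this is the first pair to show that a change of ring type at this place also stays within the scatter. No measurement is available to explain this result.

The compounds shown leave open whether any group on this nitrogen can give a step beyond the scatter, since both steps read so far lie within it. An open-chain amine such as 2-aminoethyl, a carboxylic acid or a piperidin-4-yl ring in place of piperazin-2-yl would test how far this reading holds, and whether the ring itself or its second nitrogen matters in this assay at this place.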